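The source may report more compounds than this note shows. Statements on the series, on what has been measured and on what is new or still open speak of the compounds shown alone.

Compound 1 `COc1ccc(NC(=O)Nc2nn(-c3ccccc3)c(=O)c3ccccc23)cc1`: 4%
Compound 2 `O=C(Nc1nn(-c2ccccc2)c(=O)c2ccccc12)c1ccc(Cl)cc1`: 26%
Compound 3 `COc1ccc(NC(=O)Nc2nn(-c3ccccc3)c(=O)c3ccccc23)c(OC)c1`: 29%

All three share one core and were tested in an assay on CHO cells for displacement of a labelled ligand from adenosine receptor A1 (Homo sapiens), tested at 10 uM; on this read-out lower numbers stand for less inhibition and higher numbers for more inhibition at the one concentration tested (going by the name of the read-out). Compound 3 has the highest number of the three; compound 2 lies within the scatter of it, while compound 1 sits clearly lower. Compound 4 `Cc1ccccc1NC(=O)Nc1nn(-c2ccccc2)c(=O)c2ccccc12` differs from compound 3 in one place: 2-methylphenyl in place of 2,4-dimethoxyphenyl on an amide-type nitrogen. The step that bears on this is a number 25 percentage points higher from compound 1 to compound 3 (beyond the scatter), where a methoxy was added to the phenyl on the urea; the step of a number 22 percentage points higher from compound 1 to compound 2 (beyond the scatter) concerns a different part of the molecule. Compound 4 gives up both methoxy groups and brings a methyl instead, so part of that gain is expected to be lost. A modest downward step a number 14 percentage points lower from compound 3 to compound 4 (beyond the scatter) is therefore expected. The estimate for compound 4 is 15%, with a range from 0% to 35%.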

Compound 4, a percentage reported as inhibition, at one concentration (the size of the read-out at that concentration, not a potency): 20%
Estimate against measurement, compound 4: 5 percentage points below, and the stated range covers the measured number.
By their numbers in this assay, from the lowest: compound 1; then compounds 4, 2 and 3 (each within the scatter of the next).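

On the amide-type nitrogen, 2-methylphenyl, with no hydrogen-bond acceptors, holds up against 2,4-dimethoxyphenyl, with two (a number 9 percentage points lower from compound 3 to compound 4 (within the scatter)), so the methoxy groups are not required for a number at this level. The urea of compound 4 also stands level with the amide-type link to 4-chlorophenyl in compound 2 (a number 6 percentage points lower from compound 2 to compound 4 (within the scatter)). Against 4-methoxyphenyl the change counts (a number 16 percentage points higher from compound 1 to compound 4 (beyond the scatter)), so the low number of compound 1 does not extend to every substituted phenyl here. Going by these compounds, whether an amine or a carboxylic acid on this phenyl, or a longer chain in place of the methyl, would shift the number remains open. Nothing available explains these differences.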